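Swapping a Chlorobenzyl Amide for a Pentyl Chain

The source may hold more compounds than are shown below. What is called first, only, known or untested is meant among the compounds shown, and "the series" means these compounds.

Of the compounds shown here, three sharing one core have been tested in a functional assay on QGY7701 cells (Homo sapiens) for cytotoxicity, read by MTT assay, with a stated time of 24 h; on this read-out higher numbers stand for weaker inhibition and lower numbers for stronger inhibition. Compound 2 `C=CC1=C(C(=O)NCc2ccc(Cl)cc2)C(c2ccc(F)cc2)OC1` gives 36900 nM in this assay. Compound 3 `C=CC1=C(C(=O)NC2CCCCC2)C(c2ccc(OC)c(OC)c2)OC1` gives 7490 nM, a lower number, and the gap between compound 2 and compound 3 lies beyond the usual scatter of repeated measurements. Compound 1 `C=CC1=C(C(=O)NC(C)(C)C)C(c2ccc(OC)cc2)OC1` gives > 100000 nM, which is a limit of the assay and not a measured number. Of the two measured numbers, compound 2 therefore holds the higher one, the weaker inhibition.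

Compound 4 `C=CC1=C(C(=O)NCCCCC)C(c2ccc(F)cc2)OC1` has not yet been measured. It differs from compound 2 in one place: butyl in place of 4-chlorophenyl on a saturated chain carbon bound to an amide-type nitrogen. Cut one bond further out, the same change reads as 4-chlorobenzyl to pentyl, so a ring gives way to a straight chain. Going by the values given here, no pair of measured compounds shows this change on its own, so the expectation rests on the three values alone. Because compound 2 already stands at 36900 nM, the weaker end of the measured numbers, compound 4 is expected to stay weak. The step of a 1.4-fold higher number from compound 2 to compound 4 (0.13 log units; within the scatter) is expected to be small, not far beyond the scatter, and if anything toward weaker inhibition. The estimate for compound 4 is 50000 nM, with a range from 15000 nM to 150000 nM.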

Compound 4, half-maximal inhibitory concentration: > 100000 nM
Compound 4 gave a limit, no number; the forecaster's own chance of this, stated with the estimate: 25%; at least 2.0-fold (0.30 log units) between middle value and limit.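

In this assay, going by these compounds alone, putting butyl in place of 4-chlorophenyl gives the first step in this set that can be read for a single change, and it shows an at least 2.7-fold higher number from compound 2 to compound 4 (0.43 log units; beyond the scatter). Weak as compound 2 is, its 4-chlorobenzyl group therefore cannot be exchanged for pentyl at this place without a further loss of measurable inhibition, something the three earlier compounds could not show, as each of them differs from the others in more than one place. Compound 4 gives > 100000 nM, which is a limit of the assay and not a number, so the step has a lower bound but no known upper end, and the same limit appears twice in this small set: the limit of > 100000 nM in this assay, at which 2 of the 4 values shown sit.

As far as these compounds go, what stays open is which part of the change matters, the ring or the chlorine: a plain benzyl group at this place would separate the two. Also open, from the compounds shown here alone, is whether a shorter chain such as propyl, or a chain ending in an amine, would behave as pentyl does here.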